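A few compounds are considered here, and "the series" means these few. Any claim that something is new, unique, unknown or untested is made for them only; others in the source may bear on it.

Measured compounds and values in a functional assay on Jurkat cells for inhibition of nuclear factor NF-kappa-B complex (Homo sapiens); on this read-out lower numbers stand for stronger inhibition and higher numbers for weaker inhibition:
- compound 1 `CCOC(=O)c1cnc(C)nc1NN1C(=O)C=C(C)C1=O` gives 16000 nM
- compound 2 `CCOC(=O)c1cnc(-c2cccs2)nc1NN1C(=O)C=C(C)C1=O` gives 20 nM
- compound 3 `CCOC(=O)c1cnc(-c2cccc(OC)c2)nc1NN1C(=O)C=C(C)C1=O` gives 5000 nM

Compound 3 holds the second highest of the three numbers. Its nearest neighbour is compound 1, reached by a 3.2-fold lower number from compound 1 to compound 3 (0.51 log units; beyond the scatter); its furthest is compound 2, from which it is separated by a 250-fold higher number from compound 2 to compound 3 (2.40 log units; beyond the scatter). The three compounds share one core and differ only in the group on the aromatic carbon between two ring nitrogen atoms.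

Compound 4 `CCOC(=O)c1cnc(C2CC2)nc1NN1C(=O)C=C(C)C1=O` has not yet been measured in this assay. Its change from compound 3 is cyclopropyl in place of 3-methoxyphenyl on an aromatic carbon. For the measured compounds named here, of the measured steps, the one from compound 1 to compound 3 bears most directly on this change, since compound 1 carries a methyl, another non-aromatic group, at the same place, and the step of a 3.2-fold lower number from compound 1 to compound 3 (0.51 log units; beyond the scatter) was modest. The large steps of an 800-fold lower number from compound 1 to compound 2 (2.90 log units; beyond the scatter) and a 250-fold higher number from compound 2 to compound 3 (2.40 log units; beyond the scatter) involve thiophen-2-yl and offer no closer guide. He therefore expects compound 4 to land nearer compound 1 than compound 3, with a modest rise in the number given as a 2.0-fold higher number from compound 3 to compound 4 (0.30 log units; within the scatter). His estimate for compound 4 in this assay is 10000 nM, within a range from 3000 nM to 40000 nM.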

Compound 4, half-maximal inhibitory concentration: 1000 nM
The estimate for compound 4 lay 10-fold (1.00 log units) above the measured number; the measured number lies below the stated range.
By their numbers in this assay, from the lowest: compound 2; then compound 4; then compound 3; then compound 1.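

In this assay, cyclopropyl in place of 3-methoxyphenyl gives a 5.0-fold lower number from compound 3 to compound 4 (0.70 log units; beyond the scatter), so an aromatic ring is not needed at this position for a number lower than that of the aromatic 3-methoxyphenyl group, and the group with fewer heavy atoms gives the lower number here. Methyl does not stand in for cyclopropyl, however: the step from methyl to cyclopropyl is a 16-fold lower number from compound 1 to compound 4 (1.20 log units; beyond the scatter), which separates two non-aromatic groups at the same place on the shared core. Thiophen-2-yl still keeps a clear lead, with a 50-fold higher number from compound 2 to compound 4 (1.70 log units; beyond the scatter), so across the four compounds the order follows neither aromatic character nor heavy-atom count, since cyclopropyl falls between the two aromatic groups while methyl gives the highest number of all.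

Going by these compounds, it remains open whether the low number of compound 2 is particular to thiophen-2-yl or would also be reached with furan-2-yl, and where an amine or a longer chain such as n-butyl would fall at this place. Nothing measured here accounts for this order among the four compounds.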